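The source may report more compounds than this note shows. Statements on the series, on what has been measured and on what is new or still open speak of the compounds shown alone.

Of the compounds shown here, two have been measured so far. Compound 1 `O=C1N=C(N2CCOCC2)CN1c1ccc(Cl)c(Cl)c1` was tested in a functional assay on the whole organism (strain NMRI BR) with Mus musculus as the target; on this read-out higher numbers stand for an effect only at larger amounts of compound and lower numbers for an effect already at smaller amounts; in that assay compound 1 reaches only the limit of the measurement, > 300 mg/kg, and not a number. Compound 2 `O=C1C=C(c2ccc(Cl)cc2)C(=O)N1c1ccc(Cl)cc1` likewise gives in this assay only a limit, > 300 mg/kg. Both values thus rest at the limit of > 300 mg/kg in this assay, at which 2 of the 2 values shown sit, so compound 2 stands nowhere apart from compound 1, and nothing in the numbers separates the two. Compound 3 `O=C1C=C(N2CCNCC2)C(=O)N1c1ccc(Cl)cc1` has not yet been measured in this assay. It differs from compound 2 in one place: piperazin-1-yl in place of 4-chlorophenyl on a double-bonded ring carbon. Within the data shown here, no measured pair shows the effect of such a change, and neither measured compound gives a number to build from. In this assay the expected step is a step that the limit leaves unreadable from compound 2 to compound 3, none beyond the scatter. The estimate for compound 3 in this assay is 400 mg/kg, between 100 mg/kg and 2000 mg/kg, most likely again reported only as a limit.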

Compound 3, dose for half-maximal effect: 360 mg/kg
Compound 3: the middle estimate sits 1.1-fold (0.05 log units) above what was measured; measured number inside the range.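

No step can be read from compound 2 to compound 3, because compound 2 gives only a limit and not a number: the limit of > 300 mg/kg in this assay, at which 2 of the 3 values shown sit. The compounds shown leave open how far, and in which direction, piperazin-1-yl in place of 4-chlorophenyl shifts the dose for half-maximal effect.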